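A few compounds are considered here, and "the series" means these few. Any claim that something is new, unique, unknown or untested is made for them only; others in the source may bear on it.

In an ADME assay on J774.A1 cells (Mus musculus) for cytotoxicity, read by MTT assay (a lower number here means that less compound is tolerated, a higher number that more compound is tolerated), compound 1 `O[C@H]1CCc2ccccc2[C@@H]1n1ccnc1` gives > 100 ug/mL, which is a limit of the assay and not a number. Compound 2 `O=[N+]([O-])c1ccc(O[C@H]2CCc3ccccc3[C@@H]2n2ccnc2)c(F)c1` gives 32.1 ug/mL. Compound 3 `Clc1ccc(Cl)c(CO[C@H]2CCc3ccccc3[C@@H]2n2ccnc2)c1` gives 22.3 ug/mL.

Among the measured compounds shown here, compound 3 thus stands among the two numbers measured so far; its value and that of compound 2 lie within the scatter of each other, and compound 1 sits at the limit of > 100 ug/mL in this assay, at which 1 of the 3 values shown sits. Compound 4 `Clc1cccc(CO[C@H]2CCc3ccccc3[C@@H]2n2ccnc2)c1` differs from compound 3 by hydrogen in place of chloro on an aromatic carbon. For the measured compounds named here, no step of this kind has been measured in this set, so the expected step from compound 3 to compound 4 is estimated as small, a 1.3-fold higher number from compound 3 to compound 4 (0.13 log units; within the scatter), not clearly beyond the scatter. Compound 4 is therefore expected at 30 ug/mL, between 14 ug/mL and 65 ug/mL.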

Compound 4, half-maximal cytotoxic concentration: 15.5 ug/mL
Compound 4: middle estimate off by 1.9-fold (0.29 log units), on the high side, within the range that was stated.
By their numbers in this assay, from the lowest: compounds 4, 3 and 2 (each within the scatter of the next, the first and the last beyond it). At a limit, above all of these: compound 1.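

In this assay the chloro group ortho to a large group can be exchanged for hydrogen without a change that leaves the scatter (a 1.4-fold lower number from compound 3 to compound 4 (0.16 log units; within the scatter)). The clear difference lies instead with the 3-chlorobenzyl group on the oxygen (an at least 6.4-fold lower number from compound 1 to compound 4 (0.80 log units; beyond the scatter)). That step is open-ended, since compound 1 stands at a limit of the assay: the limit of > 100 ug/mL in this assay, at which 1 of the 4 values shown sits.

The compounds shown leave open whether the remaining chloro group matters, since an unsubstituted benzyl group does not appear among them. They also leave open how an amine or a carboxylic acid on the benzyl group would read.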